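The compounds below may be only part of what the source reports. "The series", "measured", "known", "first", "only" and "open" are said of these compounds alone.

Compound 1, `O=C(NCc1ccc(S(=O)(=O)c2ccccc2)cc1)c1cc2cnccc2[nH]1`, gives 18 nM in a functional assay on A2780 cells (Homo sapiens) for cytotoxicity, read by sulforhodamine B assay, with a stated time of 72 h; a lower number here means a stronger inhibitor, a higher number a weaker inhibitor.
Compound 2, `CCCn1cc(S(=O)(=O)c2ccc(CNC(=O)N3Cc4ccncc4C3)cc2)cn1`, gives 7.3 nM in this assay.

Of the two, compound 2 has the lower number, and its gap to compound 1 lies beyond the usual scatter, so compound 2 counts as the stronger inhibitor here. Compound 3, `O=C(NCc1ccc(S(=O)(=O)N2CCC(O)CC2)cc1)N1Cc2ccncc2C1`, differs from compound 2 in one place: 4-hydroxypiperidin-1-yl in place of 1-propyl-1H-pyrazol-4-yl on a sulfonyl sulfur. Among the compounds with values here, no measured pair shows what this exchange does, so the expectation is guarded. Compound 3 is expected to come out a little weaker than compound 2, at about 20 nM, within a range from 5 nM to 80 nM. That estimate amounts to an expected step of a 2.7-fold higher number from compound 2 to compound 3 (0.44 log units; beyond the scatter), still a fairly small one.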

Compound 3, half-maximal inhibitory concentration: 98 nM
Compound 3: middle estimate off by 4.9-fold (0.69 log units), on the low side; measured number outside the range, above it.
By their numbers in this assay, from the lowest: compound 2; then compound 1; then compound 3.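

Within the data shown here, this is the first measured exchange of the group on the sulfonyl sulfur, and in this assay it brings a large loss, a 13-fold higher number from compound 2 to compound 3 (1.13 log units; beyond the scatter). The position therefore does not accept every ring equally: 4-hydroxypiperidin-1-yl, a non-aromatic six-membered ring, falls well behind 1-propyl-1H-pyrazol-4-yl, an aromatic five-membered ring. Nothing measured here explains this loss.

The compounds shown leave open whether the hydroxyl, the piperidine ring or the missing propyl chain accounts for the step. A plain piperidin-1-yl group on the same sulfur would help separate the hydroxyl from the ring.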